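A few compounds are considered here, and "the series" means these few. Any claim that something is new, unique, unknown or untested is made for them only; others in the source may bear on it.

Measured in a functional assay on NCI-H1581 cells (Homo sapiens) for antiproliferative activity, read by CCK-8 assay, with a stated time of 72 h; a lower number here means a stronger inhibitor, a higher number a weaker inhibitor:
- compound 1 `COc1cc(OC)c(Cl)c(-c2ccc3c(NC(=O)c4ccc(N5CCCCC5)cc4)n[nH]c3n2)c1Cl`: 558 nM
- compound 2 `COc1cc(OC)c(Cl)c(-c2ccc3c(NC(=O)c4ccc(N5CCN(C6CCC6)CC5)cc4)n[nH]c3n2)c1Cl`: 2.3 nM
- compound 3 `COc1cc(OC)c(Cl)c(-c2ccc3c(NC(=O)c4ccc(N5CCN(C)CC5)cc4)n[nH]c3c2)c1Cl`: 324 nM

Compound 2, at 2.3 nM, has the lowest number of the three and is the strongest inhibitor here, well clear of the other two. The next change leads to compound 4 `COc1cc(OC)c(Cl)c(-c2ccc3c(NC(=O)c4ccc(N(C)CCN(C)C)cc4)n[nH]c3n2)c1Cl`: (2-(dimethylamino)ethyl)(methyl)amino in place of 4-cyclobutylpiperazin-1-yl on an aromatic carbon. The ring system of the old group is thus replaced by an open chain, on an aromatic carbon of a six-membered aromatic ring of carbon only.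

Within the data shown here, one measured step bears on this place: a 240-fold lower number from compound 1 to compound 2 (2.38 log units; beyond the scatter), a large change. It shows that the number can move sharply with the group here, but it does not test an open chain. Compound 3 differs from compound 2 in more than one place, so it offers no clean comparison. Unlike piperidin-1-yl, the entering group matches the leaving group in nitrogen count, so a loss on the scale of that step seems unlikely. A moderate rise is expected, estimated as a 3.5-fold higher number from compound 2 to compound 4 (0.54 log units; beyond the scatter). For compound 4 the estimated value is 8 nM, with an expected range from 1.5 nM to 50 nM.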

Compound 4, half-maximal inhibitory concentration: 11 nM
Estimate against measurement, compound 4: 1.4-fold (0.14 log units) below; the measured number falls inside the stated range.
By their numbers in this assay, from the lowest: compound 2; then compound 4; then compounds 3 and 1 (each within the scatter of the next).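

In this assay, the step from the ring group to the open chain is a 4.8-fold higher number from compound 2 to compound 4 (0.68 log units; beyond the scatter), a modest change, so the intact 4-cyclobutylpiperazin-1-yl ring system is not needed for a low number at this place, para to a large group. Compared with piperidin-1-yl, the same chain still gives a 51-fold lower number from compound 1 to compound 4 (1.71 log units; beyond the scatter), a large change, so most of the gain seen with compound 2 survives with no ring at all. No measured property is available to explain either step.

The compounds shown do not separate the role of the terminal dimethylamino nitrogen from that of the chain carrying it, which a chain ending in methoxy could test. From the compounds shown here alone, it also remains open how a longer chain between the two nitrogens would fare, or a morpholine ring at this place.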